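This account rests on a few compounds, and the source may have more. Where it says the series, first, only, none or still open, it means among the compounds named here.

Compounds measured so far:
- compound 1, `COc1ccc(C(=O)Nc2ccccc2F)cc1OC1CCCC1`: 10700 nM
- compound 2, `COc1ccc(C(=O)Nc2ccncc2)cc1OC1CCCC1`: 800 nM

In an assay on isolated protein for inhibition of phosphodiesterase 4A (Sus scrofa) (on this read-out higher numbers stand for weaker inhibition and lower numbers for stronger inhibition), compound 2 gives 800 nM, the lower of the two numbers, with compound 1 at 10700 nM; the two are separated by a 13-fold lower number from compound 1 to compound 2 (1.13 log units; beyond the scatter), which is the exchange of the aryl group on the amide-type nitrogen, pyridin-4-yl in place of 2-fluorophenyl.

Compound 3, `COc1ccc(C(=O)Nc2ccncc2Cl)cc1OC1CCCC1`, keeps the pyridin-4-yl amide of compound 2 and differs from it only by chloro in place of hydrogen on an aromatic carbon, that is, on an aromatic carbon of the six-membered aromatic ring with one nitrogen, ortho to a large group and two atoms from the ring nitrogen.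

Among the compounds with values here, no measured step bears directly on this change: the single step from compound 1 to compound 2 replaces the whole ring and says nothing about a substituent added to the pyridine. Compound 3 is therefore expected to stay near compound 2, with a step of a 1.1-fold lower number from compound 2 to compound 3 (0.06 log units; within the scatter) that lies within the scatter. The estimate for compound 3 in this assay is 700 nM, with a range from 200 nM to 2500 nM.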

Compound 3, half-maximal inhibitory concentration: 16 nM
For compound 3 the middle estimate is 44-fold (1.64 log units) above the measured one; the measured number lies below the stated range.
By their numbers in this assay, from the lowest: compound 3; then compound 2; then compound 1.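

In this assay, a single chlorine atom on an aromatic carbon of the six-membered aromatic ring with 1 nitrogen, ortho to a large group and two atoms from the ring nitrogen, gives a 50-fold lower number from compound 2 to compound 3 (1.70 log units; beyond the scatter), so this position, untouched in the earlier pair, strongly affects the read-out even with a change of just 1 heavy atom. The earlier compounds shown here showed only the effect of exchanging a whole ring; the full exchange, 3-chloropyridin-4-yl in place of 2-fluorophenyl on the amide-type nitrogen, now amounts to a 670-fold lower number from compound 1 to compound 3 (2.83 log units; beyond the scatter), with the ring exchange and the added chloro pointing the same way in these three compounds. Nothing available explains why the chloro has so large an effect on this read-out.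

The compounds shown leave open whether the gain belongs to chloro itself or would also come with fluoro, bromo, methyl or methoxy in the same place. They also leave open whether a second chloro on the same ring would lower the number further or raise it again.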